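The source may hold more compounds than are shown below. What is called first, only, known or untested is meant among the compounds shown, and "the series" means these compounds.

For the measured compounds named here, in a functional assay on PC-3 cells (Homo sapiens) for antiproliferative activity, read by MTT assay, with a stated time of 48 h (on this read-out lower numbers stand for stronger inhibition and higher numbers for weaker inhibition), compound 1 `COc1ccc(CN(C(=O)Cn2cc(COc3cc(=O)oc4ccccc34)nn2)c2cc(OC)c(OC)c(OC)c2)cc1` gives 5140 nM, the lower of the two numbers measured so far. Compound 2 `COc1ccc(CN(C(=O)Cn2cc(CSc3nc4ccccc4s3)nn2)c2cc(OC)c(OC)c(OC)c2)cc1` gives 28500 nM. Compound 3 `COc1ccc(CN(C(=O)Cn2cc(CSc3nc4ccccc4o3)nn2)c2cc(OC)c(OC)c(OC)c2)cc1` has not been measured and differs from compound 1 as follows: a group of 10 heavy atoms (7 carbon, 1 nitrogen, 1 oxygen, 1 sulfur; one five-membered aromatic ring with 2 hetero atoms, one six-membered aromatic ring of carbon only) in place of a group of 12 heavy atoms (9 carbon, 3 oxygen; one six-membered aromatic ring of carbon only, one six-membered aromatic ring with 1 hetero atom), on a saturated chain carbon bound to an aromatic carbon. Going by the values given here, the only measured step that bears on this is a 5.5-fold higher number from compound 1 to compound 2 (0.74 log units; beyond the scatter), which replaces the same group at the same place. One step is thin evidence, but it points toward weaker inhibition. The expected size is a 4.3-fold higher number from compound 1 to compound 3 (0.63 log units; beyond the scatter) in this assay. Compound 3 is therefore estimated at 22000 nM, with an expected range of 8000 nM to 60000 nM.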

Compound 3, half-maximal inhibitory concentration: 5050 nM
Estimate against measurement, compound 3: 4.4-fold (0.64 log units) above; the whole stated range lies above it.
By their numbers in this assay, from the lowest: compounds 3 and 1 (each within the scatter of the next); then compound 2.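

In this assay there is a 5.6-fold lower number from compound 2 to compound 3 (0.75 log units; beyond the scatter) when 1,3-benzoxazol-2-yl replaces 1,3-benzothiazol-2-yl on a sulfur, so the weaker result of compound 2 does not hold for every such fused ring group at this position. There is also a 1.0-fold lower number from compound 1 to compound 3 (0.01 log units; within the scatter) and this lies within the scatter, so the (1,3-benzoxazol-2-yl)sulfanyl group matches the group it replaces here. No evidence is available to explain the gap between the two sulfur-linked groups.

On these data alone, whether a 1,3-benzimidazol-2-yl group on the same sulfur would fall nearer compound 3 or compound 2 remains open. So does the effect of an oxygen in place of that sulfur.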